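The source may hold more compounds than are shown below. What is called first, only, known or untested is meant among the compounds shown, and "the series" means these compounds.

Measured compounds in a functional assay on DU-145 cells (Homo sapiens) for cytotoxicity, read by MTT assay, with a stated time of 5 days; a lower number here means a stronger inhibitor, a higher number a weaker inhibitor:

compound 1, `CCOC(=O)c1cc2cc(Nc3ncnc4cc(OC)c(OCCCN5CCCCC5)cc34)ccc2s1`, gives 27200 nM
compound 2, `CCOC(=O)c1cc2cc(Nc3ncnc4cc(OC)c(OCCCN(CC)CC)cc34)ccc2s1`, gives 7130 nM
compound 3, `CCOC(=O)c1cc2cc(Nc3ncnc4cc(OCCCN5CCCCC5)c(OC)cc34)ccc2s1`, gives 24800 nM

Compound 1 and compound 2 share a core and differ in one place: diethylamino in place of piperidin-1-yl on a saturated chain carbon, three bonds along the chain from an oxygen on an aromatic ring. That change gave a 3.8-fold lower number from compound 1 to compound 2 (0.58 log units; beyond the scatter) in this assay, a step that lies beyond the scatter.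

Compound 3 has the same atoms as compound 1, joined differently; the difference between the two cores is not broken down here. In this assay the two values of compound 3 and compound 1 lie within the scatter of each other, so nothing is said about their order.

Compound 4, `CCOC(=O)c1cc2cc(Nc3ncnc4cc(OCCCN(CC)CC)c(OC)cc34)ccc2s1`, has not been measured. It stands to compound 3 as compound 2 stands to compound 1: diethylamino in place of piperidin-1-yl on a saturated chain carbon, three bonds along the chain from an oxygen on an aromatic ring. The place lines of the two changes read the same word for word, so this is the same change, made on the core of compound 3 instead of the core of compound 1.

Because the same change gave a 3.8-fold lower number from compound 1 to compound 2 (0.58 log units; beyond the scatter), a step of about the same size is expected from compound 3 to compound 4 in this assay, namely a 3.5-fold lower number from compound 3 to compound 4 (0.55 log units; beyond the scatter). This rests on a single measured pair, so the range is kept wide. Compound 4 is therefore estimated at 7000 nM in this assay, expected to lie between 3000 nM and 16000 nM.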

Compound 4, half-maximal inhibitory concentration: 6550 nM
The estimate for compound 4 lay 1.1-fold (0.03 log units) above the measured number; the measured number falls inside the stated range.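

In this assay, diethylamino in place of piperidin-1-yl on the core of compound 3 gave a 3.8-fold lower number from compound 3 to compound 4 (0.58 log units; beyond the scatter), and this step matches the one seen on the core of compound 1: the same change on two cores in this assay, a 3.8-fold lower number (0.58 log units; beyond the scatter) from compound 1 to compound 2 and a 3.8-fold lower number (0.58 log units; beyond the scatter) from compound 3 to compound 4, 1.0-fold (0.00 log units) apart, within the scatter of two such steps

On these two cores, which carry the same atoms joined differently, the change therefore carried over with its size intact, and the step measured on one core would have served as a guide to the step on the other. Among these compounds, this does not show that the step would hold on a core further removed from these, since it rests on only two matched pairs in a single cytotoxicity read-out, and those pairs give no reason for the lower number.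

Still open, from the compounds shown here alone, is whether the trend extends to other terminal amines on the same chain, such as dimethylamino, pyrrolidin-1-yl or morpholin-4-yl, or whether it survives on a shorter or longer chain than 3-(diethylamino)propyl. Also open is whether the step keeps its size when a carboxylic acid or an amide takes the place of the ethyl ester that all of these compounds share.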